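A few compounds are considered here, and "the series" means these few. Any claim that something is new, unique, unknown or untested is made for them only; others in the source may bear on it.

Measured compounds:
compound 1 `O=C(NCc1cccc(Cl)c1)c1ccc2cn(CCN3CCOC3=O)nc2c1` — 220 nM
compound 2 `O=C(NCc1cccc(Cl)c1)c1ccc2cn(CCn3cccn3)nc2c1` — 173 nM
compound 3 `CCCN(CC1CCOC1)C(=O)c1ccc2oc(NCc3cccc(Cl)c3)nc2c1` — 214 nM

In an assay on isolated protein for inhibition of thyroid hormone receptor beta (Homo sapiens), read by fluorescence, with a stated time of 30 min (on this read-out higher numbers stand for weaker inhibition and lower numbers for stronger inhibition), compound 1 gives 220 nM, compound 2 gives 173 nM and compound 3 gives 214 nM. Among the compounds with values here, the number for compound 3 lies between those of compound 1 and compound 2, and all three lie within the scatter of one another; the one step measured in this set, a 1.3-fold lower number from compound 1 to compound 2 (0.10 log units; within the scatter), is within the scatter as well.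

Compound 4 `CCCN(CC1CCOC1)C(=O)c1cc(OC)c2oc(NCc3cccc(Cl)c3)nc2c1` differs from compound 3 by methoxy in place of hydrogen on an aromatic carbon. Within the data shown here, no measured step bears on this change: the step from compound 1 to compound 2 alters a group on a saturated chain carbon of a different core, and no exchange of hydrogen for methoxy on an aromatic carbon has been measured in this set. With nothing in the data pointing either way, no step beyond the scatter is expected in this assay, and the expected step is a 1.0-fold lower number from compound 3 to compound 4 (0.01 log units; within the scatter). Compound 4 is therefore estimated at 210 nM, in the range from 80 nM to 550 nM.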

Compound 4, half-maximal inhibitory concentration: 12 nM
Compound 4: middle estimate off by 18-fold (1.24 log units), on the high side, and the stated range ends above it.
By their numbers in this assay, from the lowest: compound 4; then compounds 2, 3 and 1 (each within the scatter of the next).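

In this assay, within the data shown here, this aromatic carbon, on a six-membered aromatic ring of carbon only, ortho to a fused ring and meta to a large group, responds strongly to substitution: methoxy in place of hydrogen gives an 18-fold lower number from compound 3 to compound 4 (1.25 log units; beyond the scatter) and this contrasts with the one earlier step, a 1.3-fold lower number from compound 1 to compound 2 (0.10 log units; within the scatter) which stayed within the scatter. The entering group adds only 2 heavy atoms, with no ring and no net charge, so a small change at this position is enough for a large step. No measurement at hand speaks to what lies behind this step.

Still open, going by these compounds, is whether the step belongs to methoxy itself or would also appear with hydroxy, ethoxy, fluorine or a dimethylamino group on this carbon. Also open, on these data alone, is whether methoxy on the other aromatic carbons of this ring, or on the core of compound 1, gives a comparable step.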